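The compounds below may be only part of what the source reports. "The series", "measured", "known", "first", "only" and "open" are said of these compounds alone.

Measured so far in an assay on cells for displacement of a labelled ligand from adenosine receptor A2b (Homo sapiens), read by scintillation counting and radioligand binding, with a stated time of 30 min, tested at 10 uM; on this read-out lower numbers stand for less inhibition and higher numbers for more inhibition at the one concentration tested (going by the name of the read-out):
Compound 1, `Clc1ccc(-c2nc(N3CCCCC3)c3nc[nH]c3n2)cc1`, where compound 1 gives 1.4%.
Compound 2, `Oc1cccc(-c2nc(N3CCCCC3)c3nc[nH]c3n2)c1`, where compound 2 gives > 80%, which is a limit of the assay and not a number.
Compound 3, `Cn1cnc2c(N3CCCCC3)nc(-c3cccc(O)c3)nc21`, where compound 3 gives 29.3%.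

Compound 2 stands at the top of the numbers shown: its result is only a limit (the limit of > 80% in this assay, at which 1 of the 3 values shown sits), so how far it reaches is unknown. Both measured steps that touch it are large, a number at least 78.6 percentage points higher from compound 1 to compound 2 (beyond the scatter) and a number at least 50.7 percentage points lower from compound 2 to compound 3 (beyond the scatter).

Compound 4, `Oc1ccc(-c2nc(N3CCCCC3)c3nc[nH]c3n2)cc1`, differs from compound 2 in one place: 4-hydroxyphenyl in place of 3-hydroxyphenyl on an aromatic carbon. Neither measured step bears directly on this change. The step from compound 1 to compound 2 swaps the group and its place at once, and the step from compound 2 to compound 3 alters the shared core, not the aryl group. What the step of a number at least 78.6 percentage points higher from compound 1 to compound 2 (beyond the scatter) does show is that the aryl substituent can move this assay strongly, so a shift beyond the scatter is plausible, but its direction cannot be read from these three compounds. A loss is taken as somewhat more likely than a gain, with wide uncertainty; compound 4 is expected to give about 50%, somewhere from 15% to 85%, meaning an expected step of a number at least 30 percentage points lower from compound 2 to compound 4 (beyond the scatter).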

Compound 4, a percentage reported as inhibition, at one concentration (the size of the read-out at that concentration, not a potency): > 80%
Compound 4 was reported as a limit; the forecaster's own chance of this, stated with the estimate: 25%; middle value at least 30 percentage points away from the limit.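

In this assay compound 4 gives > 80%, which is a limit of the assay and not a number. Hydroxy in place of chloro, with the place on the phenyl ring unchanged, gives a number at least 78.6 percentage points higher from compound 1 to compound 4 (beyond the scatter), so this change of group alone is enough for a large step, something the earlier swap of group and place together could not show. Whether 3-hydroxyphenyl and 4-hydroxyphenyl differ cannot be read, because compound 2 and compound 4 both stop at the same limit: the limit of > 80% in this assay, at which 2 of the 4 values shown sit.

Still open, on these data alone, is whether an amine or a methoxy group in place of the hydroxy of 4-hydroxyphenyl would keep this result. Also open, as far as these compounds go, is whether methyl in place of hydrogen on the aromatic nitrogen, which gives a number at least 50.7 percentage points lower from compound 2 to compound 3 (beyond the scatter), would bring a similar loss with 4-hydroxyphenyl.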